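This account rests on a few compounds, and the source may have more. Where it says the series, first, only, none or still open, it means among the compounds named here.

- compound 1 `COc1ccc(CNC(=O)c2nc(Br)c3cccnc3c2N[C@H]2CC[C@H](N)CC2)cc1` gives 5000 nM
- compound 2 `CN(C)c1ccc(CNC(=O)c2nc(Br)c3cccnc3c2N[C@H]2CC[C@H](N)CC2)cc1` gives 4000 nM
- compound 3 `N[C@H]1CC[C@H](Nc2c(C(=O)NCc3cccc(C(F)(F)F)c3)nc(Br)c3cccnc23)CC1` gives 4200 nM

For the measured compounds named here, all three numbers come from a functional assay on MDA-MB-435 cells (Homo sapiens) for cytotoxicity, read by MTT assay, with a stated time of 72 h (a lower number here means a stronger inhibitor, a higher number a weaker inhibitor), and no compound stands apart from the others. Compound 3 at 4200 nM sits with the other two: the steps reaching it are a 1.2-fold lower number from compound 1 to compound 3 (0.08 log units; within the scatter) and a 1.1-fold higher number from compound 2 to compound 3 (0.02 log units; within the scatter) and both lie within the scatter.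

Compound 4 `N[C@H]1CC[C@H](Nc2c(C(=O)Nc3ccccc3)nc(Br)c3cccnc23)CC1` has not yet been measured. It carries phenyl in place of 3-(trifluoromethyl)benzyl on an amide-type nitrogen while the rest of compound 3 stays unchanged. Those two steps are the closest evidence, since each swapped the aromatic group at this end of the molecule. The remaining step, a 1.3-fold lower number from compound 1 to compound 2 (0.10 log units; within the scatter) as well, stayed within the scatter. Going by the values given here, no measured compound carries phenyl on that nitrogen, so this exact change is untested and the range must stay wide.

With no measured step beyond the scatter, the expected result is a 1.1-fold higher number from compound 3 to compound 4 (0.03 log units; within the scatter) in this assay and no real shift in either direction is expected. Compound 4 is estimated at 4500 nM with an expected range from 1800 nM to 11000 nM around that figure.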

Compound 4, half-maximal inhibitory concentration: 1000 nM
Compound 4: middle estimate off by 4.5-fold (0.65 log units), on the high side; measured number below the stated range.
By their numbers in this assay, from the lowest: compound 4; then compounds 2, 3 and 1 (each within the scatter of the next).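

In this assay, phenyl on the amide-type nitrogen stands apart from all three benzyl compounds: the steps are a 4.2-fold lower number from compound 3 to compound 4 (0.62 log units; beyond the scatter) and a 4.0-fold lower number from compound 2 to compound 4 (0.60 log units; beyond the scatter) and a 5.0-fold lower number from compound 1 to compound 4 (0.70 log units; beyond the scatter) and all three lie beyond the scatter. This end of the molecule therefore does respond to change, even though swapping the substituted benzyl groups among compounds 1, 2 and 3 had left the numbers within the scatter of one another. No measurement shown here explains this shift.

Each step to compound 4 removes the chain carbon of the benzyl group and the ring substituent together, so the two changes cannot be told apart. Unsubstituted benzyl would separate them, while a longer chain such as 2-phenylethyl would show how the number follows chain length on this nitrogen.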